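Fluoro in place of chloro at the assay limit

The compounds below may be only part of what the source reports. "The series", "measured", "known", "first", "only" and "open" are said of these compounds alone.

In an ADME assay on MIA PaCa-2 cells (Homo sapiens) for cytotoxicity, read by MTT assay, with a stated time of 72 h (on this read-out lower numbers stand for stronger inhibition and higher numbers for weaker inhibition), compound 1 `C=CCOc1cc(C2=C(c3cc(OC)c(OC)c(OC)c3)C(=O)C(O)C2)ccc1OC` gives > 100 ug/mL, which is a limit of the assay and not a number. Compound 2 `COc1ccc(C2=C(c3cc(OC)c(OC)c(OC)c3)C(=O)C(O)C2)cc1Cl` gives > 100 ug/mL in this assay, again a limit and not a number. What the series shows so far is the limit of > 100 ug/mL in this assay, at which 2 of the 2 values shown sit. For the measured compounds named here, the one measured step, a step that the two limits leave unreadable from compound 1 to compound 2, has no readable size and so gives no measure for the next change.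

Next comes compound 3 `COc1ccc(C2=C(c3cc(OC)c(OC)c(OC)c3)C(=O)C(O)C2)cc1F`, with the change (fluoro in place of chloro on an aromatic carbon). In words, this is fluoro in place of chloro on an aromatic carbon, ortho to a methoxy group, and 3-chloro-4-methoxyphenyl becomes 3-fluoro-4-methoxyphenyl. From the compounds shown here alone, no step beyond the scatter is expected in this assay, and the direction stays open, since compound 2 stands at > 100 ug/mL, a limit. Another report at the limit is the likeliest outcome. The expected change is a number no higher from compound 2 to compound 3 (the limit leaves the size open). Compound 3 is expected at 100 ug/mL, with an estimated range from 50 ug/mL to 200 ug/mL.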

Compound 3, half-maximal inhibitory concentration: 64 ug/mL
Compound 3: middle estimate off by 1.6-fold (0.19 log units), on the high side, and the stated range covers the measured number.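

In this assay compound 3 gives 64 ug/mL, the only value among the three compounds shown that is a number and not a limit, so this position, ortho to a methoxy group, can carry a substituent that brings the read-out into the measurable range. Fluoro in place of chloro gives an at least 1.5-fold lower number from compound 2 to compound 3 (0.19 log units; that floor lies within the scatter), and fluoro in place of allyloxy gives an at least 1.5-fold lower number from compound 1 to compound 3 (0.19 log units; that floor lies within the scatter). Both steps are floors only, the step between compound 1 and compound 2 cannot be read, and the true size of either change stays open: the limit of > 100 ug/mL in this assay, at which 2 of the 3 values shown sit.

The compounds shown leave open what an amine, a carboxylic acid or a longer chain in place of the fluoro would do to the number of compound 3 at this same position. From the compounds shown here alone, only this one position varies here, and the effect of a change elsewhere on the shared core of compound 3 also remains open.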